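The source may report more compounds than this note shows. Statements on the series, on what has been measured and on what is new or still open speak of the compounds shown alone.

Compound 1 `O=C(O)/C(S)=C/c1c[nH]c2cc(Cl)ccc12` and compound 2 `O=C(O)/C(S)=C/c1c[nH]c2cc(F)ccc12` share one core; compound 3 `O=C(O)/C(S)=C/c1ccc(Cl)cc1` and compound 4 `O=C(O)/C(S)=C/c1ccc(F)cc1` share another. In an assay on isolated protein for inhibition of Calpain-1 catalytic subunit (Sus scrofa) (a lower number here means a stronger inhibitor, a higher number a weaker inhibitor), compound 1 gives 100 nM, compound 2 gives 300 nM and compound 3 gives 15000 nM. The change from compound 1 to compound 2 is fluoro in place of chloro on an aromatic carbon, which produced a 3.0-fold higher number from compound 1 to compound 2 (0.48 log units; beyond the scatter). How the core of compound 3 differs from that of compound 1 is not broken down here; compound 3 simply sits well above both. The change from compound 3 to compound 4 is fluoro in place of chloro on an aromatic carbon, the same kind of change, though in compound 4 the ring is of carbon only and the group sits para to a group of 6 heavy atoms, whereas in compound 2 it is part of a fused or bridged system of two rings, meta to a fused ring and para to a fused ring. A step of a 3.0-fold higher number from compound 3 to compound 4 (0.48 log units; beyond the scatter) is expected, resting on a 3.0-fold higher number from compound 1 to compound 2 (0.48 log units; beyond the scatter) seen on the other core. Compound 4 is thus estimated at 45000 nM, between 15000 nM and 130000 nM.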

Compound 4, half-maximal inhibitory concentration: 5600 nM
Compound 4: middle estimate off by 8.0-fold (0.91 log units), on the high side; measured number outside the range, below it.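

In this assay, fluoro in place of chloro on an aromatic carbon gives a 2.7-fold lower number from compound 3 to compound 4 (0.43 log units; beyond the scatter). Set beside the earlier step, the same change runs in opposite directions on the two cores: the same change on two cores in this assay, a 3.0-fold higher number (0.48 log units; beyond the scatter) from compound 1 to compound 2 and a 2.7-fold lower number (0.43 log units; beyond the scatter) from compound 3 to compound 4, 8.0-fold (0.91 log units) apart, beyond the scatter of two such steps. A step read on one core therefore did not carry over to the other here, but this single pair of steps does not show which difference between the cores or between the surroundings of the halogen goes with the reversal, nor how any other change would carry over.

Open, going by these compounds, is whether bromo or methoxy on the same aromatic carbon would follow the order seen on each core. Also open, on these data alone, is how an amide in place of the carboxylic acid would behave on either core.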